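A few compounds are considered here, and "the series" means these few. Any claim that something is new, unique, unknown or untested is made for them only; others in the source may bear on it.

Of the compounds shown here, three on a shared core have been measured so far. In a functional assay on PANC-1 cells (Homo sapiens) for inhibition, read by MTT assay, with a stated time of 24 h, tested at 10 uM (a higher number here means more inhibition at the concentration tested (going by the name of the read-out), a lower number less inhibition), compound 1 `CC(C)=CCC1Cc2c(O)cc(=O)n(CCCO)c2CC1(C)C` gives 25.6%, compound 2 `CCOc1cc(=O)n(CCCO)c2c1CC(CC=C(C)C)C(C)(C)C2` gives 66.5% and compound 3 `CC(C)=CCC1Cc2c(OCCCNS(=O)(=O)c3ccc([N+](=O)[O-])cc3)cc(=O)n(CCCO)c2CC1(C)C` gives 47.7%. Among the compounds with values here, compound 2 stands highest of the three; its nearest neighbour is compound 3, and the single one-place step recorded, a number 40.9 percentage points higher from compound 1 to compound 2 (beyond the scatter), is large. Compound 4 `CC(C)=CCC1Cc2c(OCCCNC(=O)c3cccs3)cc(=O)n(CCCO)c2CC1(C)C` differs from compound 2 by (((thiophen-2-yl)carbonyl)amino)methyl in place of hydrogen on a saturated chain carbon, two bonds along the chain from an oxygen on an aromatic ring. The ethyl of compound 2 thus grows into a longer chain ending in a ring, and the only comparable case, compound 3 with its own long chain on that oxygen, sits well under compound 2. A moderate drop is therefore expected, a number 16.5 percentage points lower from compound 2 to compound 4 (beyond the scatter). Compound 4 is estimated at 50%, within 30% to 70%.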

Compound 4, a percentage reported as inhibition, at one concentration (the size of the read-out at that concentration, not a potency): 33.6%
Beside the measured number, compound 4's estimate is 16.4 percentage points above it; the measured number falls inside the stated range.
By their numbers in this assay, from the lowest: compounds 1 and 4 (each within the scatter of the next); then compound 3; then compound 2.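

In this assay, lengthening the ethyl on the aromatic oxygen to 3-(((thiophen-2-yl)carbonyl)amino)propyl gives a clear loss (a number 32.9 percentage points lower from compound 2 to compound 4 (beyond the scatter)). Against the plain hydrogen of compound 1, the same chain cannot be told apart (a number 8 percentage points higher from compound 1 to compound 4 (within the scatter)), so it keeps none of the gain seen with ethyl. The far end of the chain also counts, as (thiophen-2-yl)carbonyl in place of (4-nitrophenyl)sulfonyl on the amine nitrogen gives a modest change (a number 14.1 percentage points lower from compound 3 to compound 4 (beyond the scatter)). Nothing available explains these differences. Open, from the compounds shown here alone, is how a propyl or butyl group on this oxygen, or a propyl chain ending in a free amine or carboxylic acid, would compare.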